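A few compounds are considered here, and "the series" means these few. Any claim that something is new, unique, unknown or untested is made for them only; others in the source may bear on it.

Of the compounds shown here, two of a shared core have been measured in an assay on isolated protein for inhibition of Leucine-rich repeat serine/threonine-protein kinase 2 variant G2019S (Homo sapiens), read by TR-FRET and LanthaScreen, with stated times of 50 min and 30 min, in the presence of a further agent that is not named here; on this read-out lower numbers stand for stronger inhibition and higher numbers for weaker inhibition. Compound 1 `C[C@@H]1CCCN1c1c(C#N)c2c(N)nc(Nc3cn[nH]c3)nc2n1C` gives 6 nM. Compound 2 `Cn1c(N2CCCC2)c(C#N)c2c(N)ncnc21` stands at the higher of the two numbers, giving 1910 nM, a gap to compound 1 that lies beyond the scatter. Compound 3 `C[C@H]1CCCN1c1c(C#N)c2c(N)ncnc2n1C` is not yet measured; it differs from compound 2 by methyl in place of hydrogen on a saturated ring carbon, a methyl in place of hydrogen on a saturated ring carbon. Within the data shown here, no measured step of this exact kind is available, so only a small change is expected, if any, with the step of a 1.9-fold lower number from compound 2 to compound 3 (0.28 log units; within the scatter) leaning toward a lower number. Compound 3 is therefore estimated at 1000 nM, with a range from 350 nM to 2800 nM.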

Compound 3, half-maximal inhibitory concentration: 3080 nM
For compound 3 the middle estimate is 3.1-fold (0.49 log units) below the measured one; the whole stated range lies below it.
By their numbers in this assay, from the lowest: compound 1; then compounds 2 and 3 (each within the scatter of the next).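

In this assay, methyl in place of hydrogen on a saturated ring carbon, next to the ring nitrogen, gives a 1.6-fold higher number from compound 2 to compound 3 (0.21 log units; within the scatter). Pyrrolidin-1-yl and 2-methylpyrrolidin-1-yl therefore cannot be told apart on this core, the first reading of any change at this position. Nothing at hand accounts for this result. On these data alone, whether an ethyl or a hydroxymethyl group on this carbon would read the same stays open. So does whether the methyl counts for as little on the core of compound 1, which carries more than this ring.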